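Replacing a brominated ring with a two-carbon bridge to phenyl

The source may report more compounds than this note shows. Statements on the series, on what has been measured and on what is new or still open speak of the compounds shown alone.

Of the compounds shown here, three sharing one core have been tested in a functional assay on MCF7 cells (Homo sapiens) for cytotoxicity, read by MTT assay, with a stated time of 96 h; a higher number here means a weaker inhibitor, a lower number a stronger inhibitor. Among the compounds with values here, compound 1 `COc1cc(C(=O)c2cn(-c3cccc(Br)c3)cc2-c2ccccc2)cc(OC)c1OC` gives 78 nM, and compound 2 `COc1cc(C(=O)c2cn(-c3ccc(Br)cc3)cc2-c2ccccc2)cc(OC)c1OC` gives 20 nM; their only step, a 3.9-fold lower number from compound 1 to compound 2 (0.59 log units; beyond the scatter), concerns a bromine position on the ring attached to nitrogen. Compound 3 `COc1cc(C(=O)c2cn(-c3ccccc3)cc2-c2cccc(Br)c2)cc(OC)c1OC` gives 950 nM, the highest number of the three, so it is the weakest inhibitor here.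

Compound 4 `COc1cc(C(=O)c2cn(-c3ccccc3)cc2/C=C/c2ccccc2)cc(OC)c1OC` differs from compound 3 in a single place: 2-phenylethenyl in place of 3-bromophenyl on an aromatic carbon. Within the data shown here, no measured step bears directly on this change, since the one step observed alters a different part of the molecule and compounds 1 and 2 differ from compound 3 in two places rather than one. What the numbers do show is that compound 3, the only one carrying a bromine on the ring attached to carbon, is the weakest, and its number is expected to fall somewhat when that group is exchanged, giving an expected step of a 2.4-fold lower number from compound 3 to compound 4 (0.38 log units; beyond the scatter). Compound 4 is therefore estimated at 400 nM, within a range from 80 nM to 2500 nM.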

Compound 4, half-maximal inhibitory concentration: 2200 nM
The estimate for compound 4 lay 5.5-fold (0.74 log units) below the measured number; measured number inside the range.
By their numbers in this assay, from the lowest: compound 2; then compound 1; then compound 3; then compound 4.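

Within the data shown here, exchanging 3-bromophenyl for 2-phenylethenyl on this aromatic carbon gives in this assay a 2.3-fold higher number from compound 3 to compound 4 (0.36 log units; beyond the scatter) and is the only measured step at this position of the shared core. Both groups carry a six-membered aromatic ring of carbon only, but the new group adds a double bond outside that ring and the bromine is gone, so this single step cannot separate the effects of those two differences. Nothing measured here explains the higher number.

As far as these compounds go, it remains open how an amine or a carboxylic acid would fare at this position. Also open, from the compounds shown here alone, is whether 2-phenylethenyl would give a similar step in a compound carrying the 4-bromophenyl of compound 2 on the ring nitrogen.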